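Thiocarbonyl substituent change in a pyridine thiosemicarbazone series

A few compounds are considered here, and "the series" means these few. Any claim that something is new, unique, unknown or untested is made for them only; others in the source may bear on it.

Compound 1 `Cc1ccnc(/C(N)=N/NC(=S)N2CCCC2)c1` is the lower of the two numbers recorded so far: in a functional assay on A-431 cells (Homo sapiens) for cytotoxicity, read by MTT assay, with a stated time of 72 h (on this read-out higher numbers stand for weaker inhibition and lower numbers for stronger inhibition), compound 1 gives 900 nM. For the measured compounds named here, compound 2 `N/C(=N\NC(=S)N1CCSCC1)c1ccccn1` differs from it in more than one place, so no single step is drawn between them; in this assay compound 2 gives 6700 nM, a higher number, beyond the scatter.

Compound 3 `Cc1ccnc(/C(N)=N/NC(=S)N2CCOCC2)c1` is not yet measured. It differs from compound 1 as follows: morpholin-4-yl in place of pyrrolidin-1-yl on a thiocarbonyl carbon. The shared core, including the methyl-bearing pyridine of compound 1, is kept. Going by the values given here, no measured pair isolates this change, so the direction rests on compound 1 alone and on the general spread of the two numbers recorded. A modest weakening is expected, with the step of a 2.2-fold higher number from compound 1 to compound 3 (0.35 log units; beyond the scatter) judged to lie near the edge of the scatter. Compound 3 is estimated at 2000 nM in this assay, within 700 nM to 6000 nM.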

Compound 3, half-maximal inhibitory concentration: 6800 nM
The estimate for compound 3 lay 3.4-fold (0.53 log units) below the measured number; the measured number lies above the stated range.
By their numbers in this assay, from the lowest: compound 1; then compounds 2 and 3 (each within the scatter of the next).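

Morpholin-4-yl in place of pyrrolidin-1-yl on a thiocarbonyl carbon is the first single change that can be read in this assay, and it gives a 7.6-fold higher number from compound 1 to compound 3 (0.88 log units; beyond the scatter) with the shared core kept. The number at this position therefore depends on the ring it carries, but the entering ring differs in size, heavy-atom count and its oxygen all at once, so this one step cannot assign the change to any of these. Nothing available bears on why the step has this size.

Going by these compounds, whether ring size or the ring oxygen carries the step stays open, and piperidin-1-yl on the same thiocarbonyl carbon would separate the two. On these data alone, how an open-chain group such as dimethylamino would compare with either ring also remains open.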